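The source may hold more compounds than are shown below. What is called first, only, known or untested is meant among the compounds shown, and "the series" means these compounds.

Measured so far:
Compound 1 `NC(=S)N1CCCc2c(OCCCCCOc3cccc4ccccc34)cccc21`: in an ADME assay on Huh-7 cells (Homo sapiens) for cytotoxicity (on this read-out higher numbers stand for lower toxicity in this test and lower numbers for higher toxicity in this test), compound 1 gives only a limit, > 50000 nM, not a number.
Compound 2 `NC(=S)n1ccc2c(OCCCCCOc3ccc(Cl)cc3)cccc21`: in this assay compound 2 gives 24700 nM.
Compound 3 `N#Cc1cccc(C(=O)NC(=S)N2CCc3c(OCCCCCOc4ccc(Cl)cc4)cccc32)c1`: in this assay compound 3 gives 9750 nM.

Compound 3 stands lowest of the two real numbers; the nearest, compound 2, sits higher by a gap beyond the usual scatter. Compound 1 contributes only a limit (the limit of > 50000 nM in this assay, at which 1 of the 3 values shown sits), so no ordering against it is possible.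

Compound 4 `O=C(NC(=S)N1CCc2c(OCCCCCOc3ccc(Cl)cc3)cccc21)c1ccc(C(F)(F)F)cc1` differs from compound 3 in one place: 4-(trifluoromethyl)phenyl in place of 3-cyanophenyl on a carbonyl carbon. Both groups are single six-membered aromatic rings of carbon hung on the same carbonyl carbon, so the shared core and the long linker are untouched. No measured pair in this set isolates such a ring substituent swap, and nothing here gives a cause for either direction. The expectation is therefore a step no larger than the scatter, with a slight lean toward a lower number, so that compound 4 is estimated at 8000 nM, within 3000 nM to 25000 nM, a step from compound 3 of a 1.2-fold lower number from compound 3 to compound 4 (0.09 log units; within the scatter).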

Compound 4, half-maximal cytotoxic concentration: 32700 nM
Compound 4: middle estimate off by 4.1-fold (0.61 log units), on the low side; the whole stated range lies below it.
By their numbers in this assay, from the lowest: compound 3; then compounds 2 and 4 (each within the scatter of the next). At a limit, above all of these: compound 1.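

In this assay, the aromatic ring on the carbonyl carbon turns out to matter: 4-(trifluoromethyl)phenyl in place of 3-cyanophenyl gives a 3.4-fold higher number from compound 3 to compound 4 (0.53 log units; beyond the scatter) and so lower toxicity in this test. This is the first pair shown that differs in one place, and it shows that a change on this ring alone, with the shared core and linker untouched, can carry a step beyond the usual scatter. Nothing shown gives a cause for this step.

The two group names differ both in the group on the ring and in its number, so this single pair cannot tell those two changes apart. Also open, from the compounds shown here alone, is how the read-out would respond to an unsubstituted phenyl on this carbonyl carbon, or to a ring bearing an amine or a carboxylic acid.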